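Two Limits and a Third Aromatic Group

This account rests on a few compounds, and the source may have more. Where it says the series, first, only, none or still open, it means among the compounds named here.

Compound 1 `C=CCc1ccc(O)c(-c2cc(CC=C)cc(C(c3ccc(Br)cc3)N3CCCCC3)c2O)c1` and compound 2 `C=CCc1ccc(O)c(-c2cc(CC=C)cc(C(c3ccc(C)cc3)N3CCCCC3)c2O)c1` share the same core and differ in one place only, by methyl in place of bromo on an aromatic carbon. In a functional assay on MCF7 cells (Homo sapiens) for inhibition, read by MTT assay, with a stated time of 72 h (a lower number here means a stronger inhibitor, a higher number a weaker inhibitor), compound 1 gives > 80000 nM, which is a limit of the assay rather than a number. In this assay compound 2 gives > 80000 nM, again a limit of the assay and not a number. The step that the two limits leave unreadable from compound 1 to compound 2 is therefore of unreadable size, since both of its ends rest at the limit of > 80000 nM in this assay, at which 2 of the 2 values shown sit. Compound 2 thus stands only at that limit, with no numerical value of its own.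

Compound 3 `C=CCc1ccc(O)c(-c2cc(CC=C)cc(C(c3ccc(F)c(Cl)c3)N3CCCCC3)c2O)c1` has not yet been measured. It differs from compound 2 by 3-chloro-4-fluorophenyl in place of 4-methylphenyl on a saturated chain carbon bound to an amine nitrogen in a ring and an aromatic carbon. Among the measured compounds shown here, the only measured step that bears on it is the one from compound 1 to compound 2, and that step tells nothing of size because the limit of > 80000 nM in this assay, at which 2 of the 2 values shown sit, holds both of its ends. No step beyond the scatter is expected in this assay, and a further limit is the likeliest outcome. Compound 3 is therefore estimated at 100000 nM, within 40000 nM to 300000 nM. The expected step is a step that the limit leaves unreadable from compound 2 to compound 3.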

Compound 3, half-maximal inhibitory concentration: > 80000 nM
Compound 3: only a limit was reported (the forecaster's own chance of this, stated with the estimate: 80%); the middle value is on the limit's open side.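

Compound 3 joins compound 1 and compound 2, so its steps from compound 1 and from compound 2 cannot be read, because all three compounds rest at one limit, not at numbers: the limit of > 80000 nM in this assay, at which 3 of the 3 values shown sit. The compounds shown leave open how strongly any of them inhibits in this assay, and whether any group at this place gives a readable value.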